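This account rests on a few compounds, and the source may have more. Where it says the series, first, only, none or still open, it means among the compounds named here.

Compound 1 `Cn1c(SCC(=O)Nn2c(COc3ccc(Cl)cc3Cl)nc3ccccc3c2=O)nc(-c2ccccc2)c(C#N)c1=O`: 54.6%
Compound 2 `N#Cc1c(-c2ccccc2)nc(SCC(=O)Nn2c(COc3ccc(Cl)cc3Cl)nc3ccccc3c2=O)n(Cc2ccccc2)c1=O`: 77.3%
Compound 3 `Cn1c(SCC(=O)Nn2c(COc3ccc(Cl)cc3Cl)nc3ccccc3c2=O)nc(-c2ccc(O)cc2)c(C#N)c1=O`: 80%

These values come from a functional assay on the whole organism (strain albino) for inhibition, with Rattus norvegicus as the target, read by paw edema, with a stated time of 1 h, at a dose of 100 mg/kg by the oral route; a lower number here means less inhibition, a higher number more inhibition at the dose given (going by the name of the read-out). Compound 2 arises from compound 1 by one change, (phenyl in place of hydrogen on a saturated chain carbon bound to an aromatic nitrogen), and that step raised the read-out by a number 22.7 percentage points higher from compound 1 to compound 2 (beyond the scatter). The cores of compound 1 and compound 3 differ by hydroxy in place of hydrogen on an aromatic carbon, a change that on its own gave a number 25.4 percentage points higher from compound 1 to compound 3 (beyond the scatter). Compound 4 `N#Cc1c(-c2ccc(O)cc2)nc(SCC(=O)Nn2c(COc3ccc(Cl)cc3Cl)nc3ccccc3c2=O)n(Cc2ccccc2)c1=O` is not yet measured; it arises from compound 3 by the same change seen before, (phenyl in place of hydrogen on a saturated chain carbon bound to an aromatic nitrogen), at the same place. Since the value of compound 3 in this assay, 80%, already lies high on the percentage scale, the step from compound 3 to compound 4 is expected to be smaller than the earlier one, estimated at a number 8 percentage points higher from compound 3 to compound 4 (within the scatter). For compound 4 the expected result in this assay is 88%, likely between 76% and 97%.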

Compound 4, a percentage reported as inhibition, in the whole organism at one dose (the size of the read-out at that dose, not a potency): 54.6%
Compound 4: the middle estimate sits 33.4 percentage points above what was measured; the measured number lies below the stated range.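

In this assay, methyl to benzyl on the core of compound 3 gave a number 25.4 percentage points lower from compound 3 to compound 4 (beyond the scatter), the opposite direction to the same change on the core of compound 1: the same change on two cores in this assay, a number 22.7 percentage points higher (beyond the scatter) from compound 1 to compound 2 and a number 25.4 percentage points lower (beyond the scatter) from compound 3 to compound 4, 48.1 percentage points apart, beyond the scatter of two such steps The hydroxy group also failed to carry over, with a number 22.7 percentage points lower from compound 2 to compound 4 (beyond the scatter): the same change on two cores in this assay, a number 25.4 percentage points higher (beyond the scatter) from compound 1 to compound 3 and a number 22.7 percentage points lower (beyond the scatter) from compound 2 to compound 4, 48.1 percentage points apart, beyond the scatter of two such steps Each change therefore depends on the core that receives it and cannot be treated as a fixed increment in this series, though these four compounds, tested at one dose, do not show why the two changes fail to add up.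

As far as these compounds go, whether an amine or a carboxylic acid in place of the hydroxy, or an ethyl in place of the benzyl, would show the same dependence remains open. So does whether the pattern would hold at other doses or times.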